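A para-fluoro variant of a triazole-linked diterpenoid

The source may report more compounds than this note shows. Statements on the series, on what has been measured and on what is new or still open speak of the compounds shown alone.

Compound 1 `Cc1c(O)ccc2c1[C@H](Cn1cc(-c3ccccc3)nn1)[C@@]13CC(=O)[C@@](C)(CC[C@@H]21)C3` was examined in a functional assay on SMMC-7721 cells (Homo sapiens) for cytotoxicity, read by MTT assay, with a stated time of 4 days (a higher number here means a weaker inhibitor, a lower number a stronger inhibitor), where compound 1 gives only a limit, > 20000 nM. Compound 3 `Cc1ccc(S(=O)(=O)Oc2ccc3c(c2C)[C@H](Cn2cc(-c4ccccc4)nn2)[C@@]24CC(=O)[C@@](C)(CC[C@@H]32)C4)cc1` likewise reaches only a limit in this assay, > 20000 nM. The step that the two limits leave unreadable from compound 1 to compound 3 therefore cannot be read, because both values sit at the limit of > 20000 nM in this assay, at which 2 of the 3 values shown sit. For the measured compounds named here, compound 2 `C=C1C(=O)[C@]23C[C@@]1(O)CC[C@H]2c1ccc(OS(=O)(=O)c2ccc(C)cc2)c(C)c1[C@@H]3Cn1cc(-c2ccccn2)nn1`, which differs from the others in several places at once, is the only member of the set with a number rather than a limit in this assay, 2830 nM; no single step connects it to compound 1.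

Compound 4 `Cc1c(O)ccc2c1[C@H](Cn1cc(-c3ccc(F)cc3)nn1)[C@@]13CC(=O)[C@@](C)(CC[C@@H]21)C3` keeps the core of compound 1 and changes only the triazole substituent: fluoro in place of hydrogen on an aromatic carbon, so that phenyl becomes 4-fluorophenyl. Going by the values given here, none of the measured steps touches this position, and the one step that was measured, from compound 1 to compound 3, gives no readable size. Nothing in the data therefore points to a change beyond the scatter, and compound 4 is expected to remain near the limit where compound 1 sits, with a step that the limit leaves unreadable from compound 1 to compound 4 as the expected step. For compound 4 the estimate in this assay is 25000 nM, in a range from 8000 nM to 80000 nM, with a real chance that only a limit is reported again.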

Compound 4, half-maximal inhibitory concentration: > 20000 nM
Compound 4: no number, only a limit (the forecaster's own chance of this, stated with the estimate: 70%); the middle value is on the limit's open side.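

No step can be read between compound 1 and compound 4, because each gives only a limit and both sit at the same one: the limit of > 20000 nM in this assay, at which 3 of the 4 values shown sit. The compounds shown leave open whether 4-fluorophenyl in place of phenyl alters the result in this assay at all, and which of the several differences in compound 2 goes with its value of 2830 nM.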